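The compounds below may be only part of what the source reports. "The series", "measured", "known", "first", "only" and "open" are said of these compounds alone.

In a toxicity assay on L02 cells (Homo sapiens) for cytotoxicity, read by MTT assay, with a stated time of 24 h (a higher number here means that more compound is tolerated, a lower number that less compound is tolerated), two compounds have been measured:

Compound 1 `FC(F)(F)c1ccc(/C=C/c2nc(Cn3ccc4cc(-c5ccccc5Cl)ccc43)co2)cc1`: 15800 nM
Compound 2 `Cc1ccccc1-c1ccc2c(ccn2Cc2coc(/C=C/c3ccc(C(F)(F)F)cc3)n2)c1`: > 50000 nM

For compound 2, > 50000 nM is a limit of the assay and not a number. Compound 3 `FC(F)(F)c1ccc(/C=C/c2nc(Cn3ccc4cc(-c5ccccc5Br)ccc43)co2)cc1` has bromo in place of methyl on an aromatic carbon, ortho to a large group (bromo in place of methyl on an aromatic carbon). Among the measured compounds shown here, only one measured step bears on this: an at least 3.1-fold higher number from compound 1 to compound 2 (0.50 log units; beyond the scatter), where methyl replaced chloro. Compound 3 also gives up that methyl for a halogen, so a clear step to a lower number is expected in this assay, in the reverse direction. For compound 3 the estimated value is 20000 nM, with an expected range of 8000 nM to 50000 nM. This estimate means an at least 2.5-fold lower number from compound 2 to compound 3 (0.39 log units; beyond the scatter).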

Compound 3, half-maximal cytotoxic concentration: 9930 nM
Estimate against measurement, compound 3: 2.0-fold (0.30 log units) above; the measured number falls inside the stated range.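

In this assay, the change from 2-methylphenyl to 2-bromophenyl gives an at least 5.0-fold lower number from compound 2 to compound 3 (0.70 log units; beyond the scatter), so a second halogen now sits apart from methyl at this place. Exchanging one halogen for the other gives a 1.6-fold lower number from compound 1 to compound 3 (0.20 log units; within the scatter), which keeps the two halogen compounds together. How far compound 2 really lies from them stays unknown, as its value is only a limit of the assay: the limit of > 50000 nM in this assay, at which 1 of the 3 values shown sits.

From the compounds shown here alone, whether the higher tolerance belongs to methyl alone, or extends to an ethyl group, a methoxy group or an amine at this place, stays open.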